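The compounds below may be only part of what the source reports. "The series", "measured", "known", "first", "only" and "open" are said of these compounds alone.

Measured so far: compound 1 `COc1ccc([C@@H]2[C@H](Oc3ccccc3)C(=O)N2c2cc(OC)c(OC)c(OC)c2)cc1OC` with 26000 nM; compound 2 `COc1cc(N2C(=O)[C@@H](Oc3ccccc3)[C@H]2c2ccc([S+](C)[O-])cc2)cc(OC)c1OC` with 20000 nM.

In a functional assay on MCF7 cells (Homo sapiens) for antiproliferative activity, read by MTT assay, with stated times of 24 h and 72 h (on this read-out lower numbers stand for stronger inhibition and higher numbers for weaker inhibition), compound 2 gives 20000 nM, the lower of the two numbers, although its gap to compound 1 is within the scatter. Compound 3 `COc1ccc([C@@H]2[C@H](Oc3ccccc3)C(=O)N2c2cc(OC)c(OC)c(OC)c2)cc1N` differs from compound 2 by a group of 9 heavy atoms (7 carbon, 1 nitrogen, 1 oxygen; one six-membered aromatic ring of carbon only) in place of a group of 9 heavy atoms (7 carbon, 1 oxygen, 1 sulfur; one six-membered aromatic ring of carbon only), on a saturated ring carbon. Among the compounds with values here, only one measured step exists, a 1.3-fold lower number from compound 1 to compound 2 (0.11 log units; within the scatter), and it concerns an exchange at the same saturated ring carbon but between two other groups, so it bears on this change only loosely; no measured step leads to the 3-amino-4-methoxyphenyl group. On that basis the most defensible expectation is a number near the two measured ones, with a wide range to allow for the untested group. Compound 3 is estimated at 10000 nM, between 500 nM and 40000 nM. This estimate corresponds to an expected step of a 2.0-fold lower number from compound 2 to compound 3 (0.30 log units; within the scatter).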

Compound 3, half-maximal inhibitory concentration: 12200 nM
Compound 3: the middle estimate sits 1.2-fold (0.09 log units) below what was measured, and the stated range covers the measured number.
By their numbers in this assay, from the lowest: compounds 3, 2 and 1 (each within the scatter of the next, the first and the last beyond it).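

In this assay the series gains its first step beyond the scatter, with amino in place of methoxy on an aromatic carbon giving a 2.1-fold lower number from compound 1 to compound 3 (0.33 log units; beyond the scatter), a modest change from a single exchange. At the saturated ring carbon, the 3-amino-4-methoxyphenyl group does not separate from the sulfur-bearing group it replaces, as a 1.6-fold lower number from compound 2 to compound 3 (0.21 log units; within the scatter) shows, so this pair gives no ranking of the two groups. Nothing measured here accounts for either step.

As far as these compounds go, it remains open whether the modest change is particular to amino or would also appear with a hydroxyl group or a fluorine atom on that aromatic carbon. The compounds shown also leave open how the amino compound would respond to a dimethylamino group there, or to an amine in place of the phenoxy group.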